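Extending a Hexyl Amide Toward an Acetamido-Capped Chain

This account rests on a few compounds, and the source may have more. Where it says the series, first, only, none or still open, it means among the compounds named here.

Measured compounds:
compound 1 `CCCCCNC(=O)[C@H]1O[C@@H](n2cnc3c(N)ncnc32)[C@H](O)[C@@H]1O` — 12 nM
compound 2 `CCCCCCNC(=O)[C@H]1OC(n2cnc3c(N)ncnc32)[C@H](O)[C@@H]1O` — 19 nM
compound 3 `CC(=O)NCCNC(=O)[C@H]1OC(n2cnc3c(N)ncnc32)[C@H](O)[C@@H]1O` — 46 nM

In an assay on cell membranes for binding affinity to 2-oxoglutarate receptor 1 (Rattus norvegicus), read by radioligand binding (a lower number here means a stronger inhibitor, a higher number a weaker inhibitor), compound 2 stands second highest of the three numbers, close to compound 1 and further from compound 3. Compound 4 `CC(=O)NCCCCCCCCNC(=O)[C@H]1OC(n2cnc3c(N)ncnc32)[C@H](O)[C@@H]1O` differs from compound 2 by 2-acetamidoethyl in place of hydrogen on a saturated chain carbon, six bonds along the chain from an amide-type nitrogen. Going by the values given here, the only measured step that bears on this is a 2.4-fold higher number from compound 2 to compound 3 (0.38 log units; beyond the scatter), in which an acetamido group replaced butyl while the chain shortened. Compound 4 instead keeps the full hexyl chain and gains an acetamido-capped extension, so the step from compound 2 is expected to be modest, toward a somewhat higher number or none beyond the scatter, a 1.6-fold higher number from compound 2 to compound 4 (0.20 log units; within the scatter). Compound 4 is therefore estimated at 30 nM, with a range from 10 nM to 90 nM.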

Compound 4, inhibition constant: 10 nM
Compound 4: the middle estimate sits 3.0-fold (0.48 log units) above what was measured; the measured number falls inside the stated range.
By their numbers in this assay, from the lowest: compounds 4, 1 and 2 (each within the scatter of the next); then compound 3.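

In this assay, adding 2-acetamidoethyl at this chain carbon gives a 1.9-fold lower number from compound 2 to compound 4 (0.28 log units; within the scatter) and so leaves the number within the scatter of the plain hexyl amide. An acetamido end group therefore does not always go with a higher number, since 6-acetamidohexyl in place of acetamido gives a 4.6-fold lower number from compound 3 to compound 4 (0.66 log units; beyond the scatter) at the same amide. No measurement here explains why the longer chain gives the lower number. Still open, going by these compounds, is how a longer chain would behave, and whether an amine or a carboxylic acid could replace the acetamido end group without raising the number.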